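Amide substituent change on the chromone acrylamide series

The source may report more compounds than this note shows. Statements on the series, on what has been measured and on what is new or still open speak of the compounds shown alone.

Measured compounds:
compound 1 `COc1ccc(CNC(=O)/C=C/c2coc3cc(O)ccc3c2=O)cc1`, 10000 nM in a functional assay (QGY7701 cells, Homo sapiens) for inhibition, read by MTT assay, with a stated time of 48 h; on this read-out higher numbers stand for weaker inhibition and lower numbers for stronger inhibition
compound 2 `COc1ccc2c(=O)c(/C=C/C(=O)Nc3ccccc3)coc2c1`, 14000 nM
compound 3 `COc1ccc2c(=O)c(/C=C/C(=O)Nc3cc(C)ccc3C)coc2c1`, > 100000 nM

Compound 3 gives > 100000 nM in this assay, which is a limit of the assay and not a number. Within the data shown here, the one step that reaches compound 3 is an at least 7.1-fold higher number from compound 2 to compound 3 (0.85 log units; beyond the scatter), so compound 3 sits at the weak end of the set, at the limit of > 100000 nM in this assay, at which 1 of the 3 values shown sits.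

Compound 4 `COc1ccc2c(=O)c(/C=C/C(=O)NCc3ccc(F)cc3F)coc2c1` is not yet measured. It differs from compound 3 by 2,4-difluorobenzyl in place of 2,5-dimethylphenyl on an amide-type nitrogen. Among the measured compounds shown here, no measured step covers this exchange directly. For the measured compounds named here, the only related step is the one above, which moved the number to the limit; compound 4 reverses that substituent and adds a benzyl linker. Compound 1, a benzyl-type amide on a different core, gives 10000 nM, and compound 2 with plain phenyl gives 14000 nM. Compound 4 is therefore expected to return toward those numbers, an estimated step of an at least 6.6-fold lower number from compound 3 to compound 4 (0.82 log units; beyond the scatter). The estimate for compound 4 is 15000 nM, with a range from 4000 nM to 70000 nM.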

Compound 4, half-maximal inhibitory concentration: > 100000 nM
Compound 4 gave a limit, no number (the forecaster's own chance of this, stated with the estimate: 25%); middle value at least 6.6-fold (0.82 log units) from the limit.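

Replacing phenyl with 2,4-difluorobenzyl on the amide-type nitrogen gives an at least 7.1-fold higher number from compound 2 to compound 4 (0.85 log units; beyond the scatter) in this assay. Until now only 2,5-dimethylphenyl had shown such a loss on the shared core, so among these compounds the loss is not confined to the dimethyl groups or to an aromatic ring set directly on the amide-type nitrogen. Compound 3 and compound 4 both stand at a limit of the assay and not at a number, so the step between them cannot be read: the limit of > 100000 nM in this assay, at which 2 of the 4 values shown sit.

No order between 2,5-dimethylphenyl and 2,4-difluorobenzyl can be given from these limits. Also open, from the compounds shown here alone, is whether plain benzyl on the shared core, or a phenyl carrying an amine or a carboxylic acid, would stay close to compound 2 at 14000 nM.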